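Propargyl to propyl at the sulfanyl chain

The source may hold more compounds than are shown below. What is called first, only, known or untested is meant among the compounds shown, and "the series" means these compounds.

The series shares a core carrying an alkylsulfanyl chain, a hydrazone arm and a benzyl group. Compound 1 `CCCSc1nc(N/N=C/c2ccc(C)cc2)c2nnn(Cc3ccccc3)c2n1` stands at a limit: in a functional assay on MGC-803 cells (Homo sapiens) for antiproliferative activity, read by MTT assay, with a stated time of 72 h (on this read-out lower numbers stand for stronger inhibition and higher numbers for weaker inhibition), compound 1 gives > 64000 nM, which is a limit of the assay and not a number (the limit of > 64000 nM in this assay, at which 1 of the 3 values shown sits). Compound 2 `CCCSc1nc(N/N=C(\C)c2ccccc2O)c2nnn(Cc3ccccc3Cl)c2n1` gives 35000 nM in this assay. Compound 3 `C#CCSc1nc(N/N=C(\C)c2ccccc2O)c2nnn(Cc3ccccc3)c2n1` gives 3820 nM in this assay, the lowest of the two numbers shown, with compound 2 sitting beyond the scatter above it. Among the measured compounds shown here, compound 2 and compound 3 differ in more than one place, so no single step between measured compounds is available.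

Compound 4 `CCCSc1nc(N/N=C(\C)c2ccccc2O)c2nnn(Cc3ccccc3)c2n1` is not yet measured. Relative to compound 3 the change is ethyl in place of ethynyl on a saturated chain carbon bound to a sulfur. Compound 2 carries this propyl chain and gives 35000 nM, while compound 3 with the propargyl chain gives 3820 nM; the chlorine on the benzyl of compound 2 also separates the two, so the chain's own share cannot be isolated. A step toward weaker inhibition, beyond the scatter, is expected. The expected step is a 5.2-fold higher number from compound 3 to compound 4 (0.72 log units; beyond the scatter). Compound 4 is estimated at 20000 nM, within 6000 nM to 60000 nM.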

Compound 4, half-maximal inhibitory concentration: 2310 nM
The estimate for compound 4 lay 8.7-fold (0.94 log units) above the measured number; the whole stated range lies above it.
By their numbers in this assay, from the lowest: compounds 4 and 3 (each within the scatter of the next); then compound 2. At a limit, above all of these: compound 1.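

In this assay, propargyl to propyl at the sulfanyl chain can now be read as a single change, and it gives a 1.7-fold lower number from compound 3 to compound 4 (0.22 log units; within the scatter), so on this pair the loss of the triple bond outside aromatic rings does not separate the two compounds. Among the compounds shown here, the large gap between the propyl compounds instead goes with the benzyl substituent, where hydrogen in place of chloro on an aromatic carbon gives a 15-fold lower number from compound 2 to compound 4 (1.18 log units; beyond the scatter), a step that the earlier compounds could not separate from the chain change. The group on a nitrogen on an aromatic ring also matters in the propyl series, with an at least 27-fold lower number from compound 1 to compound 4 (1.44 log units; beyond the scatter), but compound 1 stands at a limit, which is not a number, so this step starts from that limit: the limit of > 64000 nM in this assay, at which 1 of the 4 values shown sits.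

With only propargyl and propyl shown at the sulfanyl chain, the tolerance of this position to a longer chain such as pentyl, or to a chain ending in an amine or a carboxylic acid, remains open. Also open, as far as these compounds go, is whether the chloro step holds with the propargyl chain, and whether fluoro or methoxy on the benzyl group would follow chloro.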